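The source may hold more compounds than are shown below. What is called first, only, known or untested is meant among the compounds shown, and "the series" means these compounds.

Measured so far:
- Compound 1 `CCCCCCCCCn1cc(COC[C@@H]2OC[C@H](N)[C@@H]2O)nn1`: 12400 nM
- Compound 2 `CCCCCCCn1cc(COC[C@@H]2OC[C@H](N)[C@H]2O)nn1`: > 128000 nM (a limit, not a number)
- Compound 3 `CCCCCCCCn1cc(COC[C@@H]2OC[C@H](N)[C@H]2O)nn1`: > 128000 nM (a limit, not a number)

All three were tested in a functional assay on MCF7 cells (Homo sapiens) for antiproliferative activity, read by MTT assay, with a stated time of 48 h; on this read-out lower numbers stand for stronger inhibition and higher numbers for weaker inhibition. Compound 3 stands at the limit of > 128000 nM in this assay, at which 2 of the 3 values shown sit. It therefore has no exact position on the scale, and the same is true of compound 2.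

The next compound, compound 4 `CCCCCCCCCn1cc(COC[C@@H]2OC[C@H](N)[C@H]2O)nn1`, differs from compound 3 by a single change: methyl in place of hydrogen on a saturated chain carbon, eight bonds along the chain from an aromatic nitrogen. In words, this is methyl in place of hydrogen on a saturated chain carbon, eight bonds along the chain from an aromatic nitrogen.

Within the data shown here, the one measured step of this kind places the same swap seven bonds along the chain from an aromatic nitrogen: a step that the two limits leave unreadable from compound 2 to compound 3. It offers no size to carry over, so any forecast is loose.

Among the measured compounds shown here, compound 1 gives the only readable number here, 12400 nM, which shows that activity can be measured. A shift towards stronger inhibition is therefore expected, but a further limit remains quite possible.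

The expected change is an at least 2.8-fold lower number from compound 3 to compound 4 (0.45 log units; beyond the scatter). The estimated value for compound 4 is 45000 nM, with an expected range from 12000 nM to 128000 nM.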

Compound 4, half-maximal inhibitory concentration: > 128000 nM
Compound 4 ended at the assay's limit; the forecaster's own chance of this, stated with the estimate: 45%; middle value at least 2.8-fold (0.45 log units) away from the limit.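

In this assay compound 4 gives > 128000 nM, which is a limit and not a number, and it joins most of the set there: the limit of > 128000 nM in this assay, at which 3 of the 4 values shown sit.

Extending the chain by a methyl at this place, eight bonds along the chain from an aromatic nitrogen, therefore still gives no readable value, and the steps to compound 4 from compound 2 and from compound 3 cannot be read. The new information lies in the comparison with compound 1, which carries the same chain: the result is an at least 10-fold higher number from compound 1 to compound 4 (1.01 log units; beyond the scatter), a large step, and it can be traced to the drawn configuration at a single saturated ring carbon, the one stereocentre that is S in compound 1 and R in compound 4: the fact that compounds 1 and 4 differ only in the configuration as drawn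

Still open, on these data alone, is whether the configuration of compound 1 would also give a readable value with the shorter chains of compound 2 and compound 3. As far as these compounds go, it is equally open whether a longer chain, such as decyl or dodecyl, on the configuration of compound 4 would bring a value below the limit.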